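This account rests on a few compounds, and the source may have more. Where it says the series, first, only, none or still open, it means among the compounds named here.

Going by the values given here, in an ADME assay on Huh-7 cells (Homo sapiens) for cytotoxicity (on this read-out lower numbers stand for higher toxicity in this test and higher numbers for lower toxicity in this test), compound 3 `Cc1ccccc1CNCc1cc(=O)c2c(O)c(O)ccc2o1` gives 52200 nM, the only actual number among the three measured compounds. Compound 1 `O=c1cc(CNCc2ccccc2)oc2ccc(O)c(O)c12` reaches only a limit of the assay, > 100000 nM. Compound 2 `O=c1cc(CNCc2ccccc2O)oc2ccc(O)c(O)c12` likewise reaches only a limit, > 100000 nM. Both sit at the limit of > 100000 nM in this assay, at which 2 of the 3 values shown sit, so the two steps toward compound 3 can be read only as floors: an at least 1.9-fold lower number from compound 1 to compound 3 (0.28 log units; that floor lies within the scatter), with methyl in place of hydrogen on an aromatic carbon, and an at least 1.9-fold lower number from compound 2 to compound 3 (0.28 log units; that floor lies within the scatter), with methyl in place of hydroxy on an aromatic carbon. Compound 4 `O=c1cc(CNCc2cccc(Cl)c2)oc2ccc(O)c(O)c12` differs from compound 3 by 3-chlorophenyl in place of 2-methylphenyl on a saturated chain carbon bound to an amine nitrogen. Among the compounds with values here, neither floor rises beyond the scatter, and no measured step exchanges one substituted phenyl for another, so compound 4 is expected to move by a 1.3-fold higher number from compound 3 to compound 4 (0.13 log units; within the scatter), which is nothing beyond the scatter. Compound 4 is therefore estimated to give 70000 nM in this assay, within a range from 30000 nM to 150000 nM.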

Compound 4, half-maximal cytotoxic concentration: > 100000 nM
Compound 4: no number, only a limit; the forecaster's own chance of this, stated with the estimate: 40%; middle value at least 1.4-fold (0.15 log units) from the limit.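

In this assay, going by these compounds alone, 3-chlorophenyl in place of 2-methylphenyl on a saturated chain carbon bound to an amine nitrogen gives the only readable step here that exchanges one substituted phenyl for another, an at least 1.9-fold higher number from compound 3 to compound 4 (0.28 log units; that floor lies within the scatter) and that floor lies within the scatter. Within the data shown here, this change therefore shows no effect beyond the scatter, and compound 3 remains the only compound with an actual number. The steps to compound 4 from compound 1 and from compound 2 cannot be read, and the series now rests largely on a single limit: the limit of > 100000 nM in this assay, at which 3 of the 4 values shown sit.

From the compounds shown here alone, every readable step is a floor within the scatter, so the size of any effect at this position remains open. Going by these compounds, whether a carboxylic acid or an amine on the phenyl, or a longer chain before it, would give a number clearly apart from compound 3 also remains open.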